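The source may report more compounds than this note shows. Statements on the series, on what has been measured and on what is new or still open speak of the compounds shown alone.

Compound 1 `Cc1cccc(NC(=O)Nc2cccc(CNc3ncnc4ccccc34)c2)c1` and compound 2 `COc1cc2ncnc(NCc3cccc(NC(=O)Nc4ccccc4C)c3)c2cc1OC` give no numbers in a functional assay on HepG2 cells (Homo sapiens) for antiproliferative activity, read by MTT assay; on this read-out higher numbers stand for weaker inhibition and lower numbers for stronger inhibition. In this assay compound 1 gives > 50000 nM, which is a limit of the assay rather than a number. Compound 2 gives > 50000 nM, also a limit. Compound 3 `COc1ccccc1NC(=O)Nc1cccc(CNc2ncnc3cc(OC)c(OC)cc23)c1` is the only compound with a measured value, 27200 nM, so it stands alone on the numbers shown, with the limit of > 50000 nM in this assay, at which 2 of the 3 values shown sit, behind the other two. Within the data shown here, the single measured step, an at least 1.8-fold lower number from compound 2 to compound 3 (0.26 log units; that floor lies within the scatter), starts from a limit and therefore gives no firm size. Compound 4 `COc1cc2ncnc(NCc3cccc(NC(=O)Nc4ccc(Cl)cc4)c3)c2cc1OC` differs from compound 3 by 4-chlorophenyl in place of 2-methoxyphenyl on an amide-type nitrogen. Among the measured compounds shown here, no measured step covers this change, so a step of a 1.1-fold higher number from compound 3 to compound 4 (0.04 log units; within the scatter) is expected, no larger than the scatter. Compound 4 is thus estimated at 30000 nM, between 10000 nM and 90000 nM.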

Compound 4, half-maximal inhibitory concentration: > 50000 nM
Compound 4: only a limit was reported; the forecaster's own chance of this, stated with the estimate: 40%; middle value at least 1.6-fold (0.22 log units) away from the limit.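

Replacing 2-methoxyphenyl with 4-chlorophenyl on the amide-type nitrogen gives an at least 1.8-fold higher number from compound 3 to compound 4 (0.26 log units; that floor lies within the scatter), and since this step ends at a limit, only its smallest possible size is known. The step from compound 2 to compound 4 cannot be read, as both its ends are limits. With this result, the only measured number among these ureas remains that of compound 3, and compound 4 adds one more limit: the limit of > 50000 nM in this assay, at which 3 of the 4 values shown sit.

The compounds shown leave open whether the swap of methoxy for chlorine or the different ring position matters more. They also leave open whether a phenyl carrying an amine or a carboxylic acid on this nitrogen would give a measured number.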